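The source may report more compounds than this note shows. Statements on the series, on what has been measured and on what is new or still open speak of the compounds shown alone.

In a functional assay on MOLT-4 cells (Homo sapiens) (on this read-out higher numbers stand for weaker inhibition and lower numbers for stronger inhibition), compound 1 `O=C(/C=C/c1ccc(Br)cc1)Oc1ccc(/C=C2\CCCCC2=O)cc1` gives 180000 nM and compound 2 `CN(C)CC1CCC/C(=C\c2ccc(OC(=O)/C=C/c3ccc(Br)cc3)cc2)C1=O` gives 3060 nM as the lower of the two numbers. For the measured compounds named here, the only measured step is a 59-fold lower number from compound 1 to compound 2 (1.77 log units; beyond the scatter) and it is large. Compound 3 `COc1ccc(C(=O)Oc2ccc(/C=C3\CCCC(CN(C)C)C3=O)cc2)cc1` keeps the (dimethylamino)methyl of compound 2 but carries 4-methoxyphenyl in place of 2-(4-bromophenyl)ethenyl on a carbonyl carbon, a change counted as 4-methoxyphenyl in place of 2-(4-bromophenyl)ethenyl on a carbonyl carbon in full. Going by the values given here, the measured step lies elsewhere in the structure, so it sets no size for this change, and no measured pair varies this group. The data favour no direction, so no step beyond the scatter is expected, though the uncertainty is wide. The expected step is a 1.0-fold lower number from compound 2 to compound 3 (0.01 log units; within the scatter) by this estimate. In this assay compound 3 is estimated at 3000 nM with 1000 nM to 10000 nM as its expected range.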

Compound 3, half-maximal inhibitory concentration: 2360 nM
Beside the measured number, compound 3's estimate is 1.3-fold (0.10 log units) above it; measured number inside the range.
By their numbers in this assay, from the lowest: compounds 3 and 2 (each within the scatter of the next); then compound 1.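

In this assay, for the compounds shown here, the carbonyl carbon whose other neighbours are oxygen next to a carbonyl group is varied for the first time, and the exchange gives a 1.3-fold lower number from compound 2 to compound 3 (0.11 log units; within the scatter). The earlier step touched only a saturated ring carbon, whereas this one shows that, with the (dimethylamino)methyl kept, 4-methoxyphenyl and 2-(4-bromophenyl)ethenyl cannot be told apart on this read-out, even though the bromine and the double bond outside aromatic rings leave and an oxygen enters. Nothing at hand offers an explanation for this result.

The compounds shown carry 4-methoxyphenyl only together with the (dimethylamino)methyl, so whether the same exchange would read alike on the core of compound 1 stays open. Also open, on these data alone, is how an amine or a carboxylic acid on the aromatic ring of this group would read.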